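Sulfamate series: second benzyl exchange on the aryl amine

This account rests on a few compounds, and the source may have more. Where it says the series, first, only, none or still open, it means among the compounds named here.

Measured:
Compound 1 `NS(=O)(=O)Oc1ccc2c(c1)CN(C(=O)c1cccc(N(Cc3ccccc3)Cc3ccco3)c1)CC2` gives 27.5% in an assay on HEK293 cells for inhibition of Steryl-sulfatase (Homo sapiens), tested at 0.1 uM; a lower number here means a weaker effect, a higher number a stronger effect of the compound at the concentration tested.
Compound 2 `CN(C)CCN(Cc1ccccc1)c1cccc(C(=O)N2CCc3ccc(OS(N)(=O)=O)cc3C2)c1` gives 0% in this assay.

Compound 2 stands lowest of the two numbers; the nearest is compound 1, the step being a number 27.5 percentage points lower from compound 1 to compound 2 (beyond the scatter). Compound 3 `CN(C)CCN(CCN(C)C)c1cccc(C(=O)N2CCc3ccc(OS(N)(=O)=O)cc3C2)c1` differs from compound 2 by (dimethylamino)methyl in place of phenyl on a saturated chain carbon bound to a nitrogen on an aromatic ring. For the measured compounds named here, only one measured step bears on this: a number 27.5 percentage points lower from compound 1 to compound 2 (beyond the scatter), which also brought (dimethylamino)methyl onto a saturated chain carbon bound to a nitrogen on an aromatic ring and lowered inhibition beyond the scatter. As compound 2 already sits at the floor, no step beyond the scatter is expected, a number 3 percentage points higher from compound 2 to compound 3 (within the scatter). Compound 3 is estimated at 3%, within 0% to 15%.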

Compound 3, a percentage reported as inhibition, at one concentration (the size of the read-out at that concentration, not a potency): 0%
Estimate against measurement, compound 3: 3 percentage points above, within the range that was stated.
By their numbers in this assay, from the lowest: compounds 2 and 3 (each within the scatter of the next); then compound 1.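

In this assay, benzyl to 2-(dimethylamino)ethyl at this position reads as no change at the digits printed from compound 2 to compound 3 (within the scatter). Compound 2 and compound 3 both sit at the floor of the read-out, so with one 2-(dimethylamino)ethyl already on the nitrogen, this second exchange cannot be ranked, and the retained benzyl of compound 2 gives no readable inhibition. Nothing available bears on the reason for this result.

Open, as far as these compounds go, is whether a thiophen-2-ylmethyl or a plain ethyl chain in place of the 2-(dimethylamino)ethyl would lift inhibition off the floor. Also open, from the compounds shown here alone, is how a carboxylic acid on this chain would read.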